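The compounds below may be only part of what the source reports. "The series", "measured", "known", "first", "only" and "open" are said of these compounds alone.

Working notes on the series. Compound 1 `Cc1cccc(CCC(=O)N2CCN(c3ccc(C(F)(F)F)cc3[C@@H](N)CC(C)C)CC2)c1` in an assay on HEK293 cells for displacement of a labelled ligand from Melanocortin receptor 4 (Homo sapiens) (a lower number here means a stronger inhibitor, a higher number a weaker inhibitor), gives 2100 nM. Compound 2 `CCC(C)[C@H](NCc1ccccc1F)c1cc(C(F)(F)F)ccc1N1CCN(C(=O)CCc2ccc(Cl)cc2Cl)CC1` reaches only the limit of this assay, > 10000 nM, which is a limit and not a number (the limit of > 10000 nM in this assay, at which 1 of the 3 values shown sits). Compound 3 `CCC(C)[C@H](NC[C@H]1CCCN1)c1cc(C(F)(F)F)ccc1N1CCN(C(=O)CCc2ccc(Cl)cc2Cl)CC1` gives 110 nM. Within the data shown here, the single step between measured compounds that differ in one place is an at least 90-fold lower number from compound 2 to compound 3 (1.95 log units; beyond the scatter), and it comes with pyrrolidin-2-yl in place of 2-fluorophenyl on a saturated chain carbon bound to an amine nitrogen. Compound 3 therefore holds the lowest of the two numbers; compound 1 is the nearest and stands higher, and the remaining value is a limit.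

Compound 4 `CC(C)C[C@H](NC(=O)CCN)c1cc(C(F)(F)F)ccc1N1CCN(C(=O)CCc2ccc(Cl)cc2Cl)CC1` is not yet measured. It differs from compound 3 as follows: 1-(((2-aminoethyl)carbonyl)amino)-3-methylbutyl in place of 2-methyl-1-(((pyrrolidin-2-yl)methyl)amino)butyl on an aromatic carbon. Among the measured compounds shown here, the only measured step bears on it indirectly: it shows that exchanging the group on the saturated chain carbon bound to the amine nitrogen can move this assay a great deal, in either direction. Compound 4 keeps a primary amine within the 1-(((2-aminoethyl)carbonyl)amino)-3-methylbutyl group, but through an amide rather than a secondary amine, and compound 1, with its own amine-bearing group at the same aromatic carbon, gives 2100 nM. The expected step is a 5.5-fold higher number from compound 3 to compound 4 (0.74 log units; beyond the scatter), toward a higher number. Compound 4 is estimated at 600 nM, with a range of 120 nM to 3000 nM.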

Compound 4, inhibition constant: 25 nM
For compound 4 the middle estimate is 24-fold (1.38 log units) above the measured one, and the stated range ends above it.
By their numbers in this assay, from the lowest: compound 4; then compound 3; then compound 1. At a limit, above all of these: compound 2.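

In this assay, the group on an aromatic carbon ortho to a large group and meta to a trifluoromethyl group can lose its ring and take a carbonyl on the nitrogen with no loss of strength, as shown by a 4.4-fold lower number from compound 3 to compound 4 (0.64 log units; beyond the scatter); the earlier compounds showed change only in what the secondary amine carries, not in the amine link itself. The step comes with the same counted hydrogen-bond donors, acceptors and net charge on both sides, so the five-membered non-aromatic ring of the leaving group is not required for a value in this range, at least with the 1-(((2-aminoethyl)carbonyl)amino)-3-methylbutyl group in its place. Nothing measured in this set gives a reason for the step.

The compounds shown leave open how the step divides among the carbonyl, the loss of the ring and the change from 2-methylbutyl to 3-methylbutyl, since all three change together. They also leave open whether the primary amine matters, which a hydroxyl or a dimethylamino group in its place, or a longer chain before it, would address.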